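The source may hold more compounds than are shown below. What is called first, only, known or untested is meant among the compounds shown, and "the series" means these compounds.

Measured compounds:
compound 1 `Cc1nnc(SCc2ccccc2Cl)n1N1C(=O)c2ccccc2C1=O` — > 200000 nM
compound 2 `CCOC(=O)CSc1nnc(CC)n1N1C(=O)c2ccccc2C1=O` — > 200000 nM
compound 3 `C=CCSc1nnc(-c2cc(OC)c(OC)c(OC)c2)n1N1C(=O)c2ccccc2C1=O` — > 200000 nM

All three values come from a functional assay on A549 cells (Homo sapiens) for cytotoxicity, read by MTT assay, with a stated time of 48 h; a lower number here means a stronger inhibitor, a higher number a weaker inhibitor. Each of them is a limit of this assay, not a number: compound 1 returns > 200000 nM, a limit. Compound 2 returns > 200000 nM, also a limit. Compound 3 returns > 200000 nM, again a limit. Where compound 3 stands is therefore only this: at the limit, together with the other two, as summed up in the limit of > 200000 nM in this assay, at which 3 of the 3 values shown sit. Among the compounds with values here, no step between measured compounds can be read from these values, and no compound among them can be ranked against another.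

Compound 4 `C#CCSc1nnc(-c2cc(OC)c(OC)c(OC)c2)n1N1C(=O)c2ccccc2C1=O` is not yet measured in this assay. It differs from compound 3 by ethynyl in place of vinyl on a saturated chain carbon bound to a sulfur; read one bond further out, allyl becomes propargyl. Within the data shown here, with no measured step available, the expected step of a number no higher from compound 3 to compound 4 (the limit leaves the size open) is none beyond the scatter. For compound 4 the estimate is 200000 nM, with a range from 50000 nM to 400000 nM, and most likely this assay will again report only a limit.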

Compound 4, half-maximal inhibitory concentration: > 200000 nM
Compound 4: no number, only a limit; the forecaster's own chance of this, stated with the estimate: 80%; the middle value sits exactly at the limit.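

In this assay, within the data shown here, compound 4 gives > 200000 nM, a limit and not a number, and no step from compound 3 to compound 4 can be read. The compounds shown leave open whether any change on the shared core brings a value off this limit: the limit of > 200000 nM in this assay, at which 4 of the 4 values shown sit.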